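Same Chloro Shift on a Second Core

This account rests on a few compounds, and the source may have more. Where it says the series, first, only, none or still open, it means among the compounds named here.

Compound 1 `Oc1ccc(-c2cc(-c3cccs3)nc(-c3ccccc3Cl)c2)cc1` and compound 2 `Oc1ccc(-c2cc(-c3ccc(Cl)cc3)nc(-c3cccs3)c2)cc1` share a core in which, in the words of the change (4-chlorophenyl in place of 2-chlorophenyl on an aromatic carbon), 4-chlorophenyl takes the place of 2-chlorophenyl on an aromatic carbon next to the ring nitrogen, meta to a 4-hydroxyphenyl group and meta to a thiophen-2-yl group. In an ADME assay on HEK293 cells (Homo sapiens) for cytotoxicity, read by CCK-8 assay and cell counting, with a stated time of 2 days (on this read-out lower numbers stand for stronger inhibition and higher numbers for weaker inhibition), compound 1 gives 5220 nM, and compound 2 gives 4520 nM; the step of a 1.2-fold lower number from compound 1 to compound 2 (0.06 log units; within the scatter) stays within the scatter. Compound 3 `Oc1cccc(-c2cc(-c3cccnc3)nc(-c3ccccc3Cl)c2)c1` rests on a different core, and the difference between the two cores is not broken down here; in this assay compound 3 stands at "not determined" (no result reported), so no number is reported for it. Compound 4 `Oc1cccc(-c2cc(-c3ccc(Cl)cc3)nc(-c3cccnc3)c2)c1` stands to compound 3 as compound 2 stands to compound 1: the change 4-chlorophenyl in place of 2-chlorophenyl on an aromatic carbon is the same kind of change, here next to the ring nitrogen, meta to a 3-hydroxyphenyl group and meta to a pyridin-3-yl group. Since compound 3 carries no number, only the unchanged values of compounds 1 and 2 can guide an expectation. Compound 4 is estimated to fall near 5000 nM, between 2000 nM and 15000 nM.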

Compound 4, half-maximal inhibitory concentration: 39500 nM
Compound 4: the middle estimate sits 7.9-fold (0.90 log units) below what was measured; the measured number lies above the stated range.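

In this assay, for the compounds shown here, compound 3 stands at "not determined" (no result reported), so no step from it to compound 4 can be read. The compounds shown leave open whether 4-chlorophenyl in place of 2-chlorophenyl acts on the core of compound 3 as it does on the core of compound 1. No supporting information bears on the result for compound 4.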